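The source may hold more compounds than are shown below. What is called first, only, known or untested is meant among the compounds shown, and "the series" means these compounds.

Values measured so far in an ADME assay on microsomes from liver (Rattus norvegicus) for metabolic stability, using NADPH; on this read-out lower numbers stand for slow clearance and higher numbers for fast clearance:

Compound 1 `COC(=O)c1nc(-c2ccco2)c(C(F)(F)F)cc1N`: > 0.7 mL/min/kg, which is a limit of the assay.
Compound 2 `CNC(=O)c1nc(Br)c(C(F)(F)F)cc1N`: 0.1 mL/min/kg.

Among the measured compounds shown here, compound 2 provides the only actual number in this assay, so there is no measured step to serve as a guide. Compound 3 `Nc1cc(C(F)(F)F)c(Br)nc1C(=O)NCCC(F)(F)F` is still to be measured. It differs from compound 2 on a saturated chain carbon bound to an amide-type nitrogen, where 2,2,2-trifluoroethyl stands in place of hydrogen (2,2,2-trifluoroethyl in place of hydrogen on a saturated chain carbon bound to an amide-type nitrogen). The methyl of compound 2 thus becomes 3,3,3-trifluoropropyl. With compound 2 at 0.1 mL/min/kg as the sole starting point, the expectation is a rise toward faster clearance, beyond the usual scatter but not a large one. The expected change is a 3.0-fold higher number from compound 2 to compound 3 (0.48 log units; beyond the scatter). For compound 3 the estimated clearance is 0.3 mL/min/kg, with an expected range of 0.1 mL/min/kg to 0.7 mL/min/kg.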

Compound 3, clearance: 0.0558 mL/min/kg
Beside the measured number, compound 3's estimate is 5.4-fold (0.73 log units) above it; the whole stated range lies above it.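

At this position, on a saturated chain carbon bound to an amide-type nitrogen, this assay now gives its first reading of a single change: a 1.8-fold lower number from compound 2 to compound 3 (0.25 log units; within the scatter). Adding 2,2,2-trifluoroethyl, which turns methyl into 3,3,3-trifluoropropyl and brings 5 heavy atoms, therefore leaves clearance indistinguishable from that of compound 2, something no earlier pair could show. Compound 1 differs from compound 2 and compound 3 in more than one place and carries only a limit, so it adds no step: the limit of > 0.7 mL/min/kg in this assay, at which 1 of the 3 values shown sits.

On these data alone, whether a hydroxyl or an amine on this chain, or a longer chain ending in trifluoromethyl, would stay as close to compound 2 remains open. Also open, as far as these compounds go, is how clearance would respond if chlorine took the place of the bromine shared by compound 2 and compound 3.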